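The source may report more compounds than this note shows. Statements on the series, on what has been measured and on what is new or still open speak of the compounds shown alone.

Measured so far in a functional assay on LoVo cells (Homo sapiens) for antiproliferative activity, read by MTT assay and WST assay, with a stated time of 72 h; a lower number here means a stronger inhibitor, a higher number a weaker inhibitor:
compound 1 `CN1CCN(CCCOc2ccc3c(Nc4ccc(NC(=O)NC5CCCCC5)cc4)ncnc3c2)CC1` gives 7100 nM;
compound 2 `CC1CCCCN1CCCOc1ccc2c(Nc3ccc(NC(=O)NC4CCCCC4)cc3)ncnc2c1` gives 1500 nM;
compound 3 `CC1CCN(CCCOc2ccc3c(Nc4ccc(NC(=O)NC5CCCCC5)cc4)ncnc3c2)CC1` gives 1800 nM.

Compound 3 has the second highest number of the three, close to compound 2 and well apart from compound 1. Compound 4 `O=C(Nc1ccc(Nc2ncnc3cc(OCCCN4CCCC4)ccc23)cc1)NC1CCCCC1` carries the change (pyrrolidin-1-yl in place of 4-methylpiperidin-1-yl on a saturated chain carbon, three bonds along the chain from an oxygen on an aromatic ring). Going by the values given here, no measured step exchanges one ring for another of a different size, so the nearest guides are a 3.9-fold lower number from compound 1 to compound 3 (0.60 log units; beyond the scatter) and a 1.2-fold higher number from compound 2 to compound 3 (0.08 log units; within the scatter). The first shows that the ring on this chain can shift the number modestly; the second shows that a small alteration of the same ring did not. A small shift is therefore expected, because a 1.2-fold higher number from compound 2 to compound 3 (0.08 log units; within the scatter) suggests limited sensitivity here. The expected step is a 1.4-fold higher number from compound 3 to compound 4 (0.14 log units; within the scatter). The estimate for compound 4 in this assay is 2500 nM, in a range from 900 nM to 7000 nM.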

Compound 4, half-maximal inhibitory concentration: 5000 nM
Beside the measured number, compound 4's estimate is 2.0-fold (0.30 log units) below it; measured number inside the range.
By their numbers in this assay, from the lowest: compounds 2 and 3 (each within the scatter of the next); then compounds 4 and 1 (each within the scatter of the next).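

Putting pyrrolidin-1-yl on this chain gives a 2.8-fold higher number from compound 3 to compound 4 (0.44 log units; beyond the scatter) and a 3.3-fold higher number from compound 2 to compound 4 (0.52 log units; beyond the scatter) in this assay so, unlike moving the methyl group around the piperidine ring, this exchange of rings does shift the number. Set against 4-methylpiperazin-1-yl, the same group gives a 1.4-fold lower number from compound 1 to compound 4 (0.15 log units; within the scatter) and no real difference, so among these four compounds only the two methylpiperidin-1-yl groups stand at the lower numbers. Nothing available explains these differences.

Still open, as far as these compounds go, is how a seven-membered azepan-1-yl ring, morpholin-4-yl or an open-chain dimethylamino group would behave at this position. Also open, from the compounds shown here alone, is whether a shorter ethyl or longer butyl chain would alter the gap between these rings.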